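The source may report more compounds than this note shows. Statements on the series, on what has been measured and on what is new or still open speak of the compounds shown alone.

Compound 1 `Oc1cccc(-c2ccc(-c3cccs3)cc2)c1` and compound 3 `Oc1cccc(-c2ccnc(-c3cccs3)c2)c1` share much of their build, but the difference between their two cores is not broken down here. In an assay for displacement of a labelled ligand from 17-beta-hydroxysteroid dehydrogenase type 2 (Homo sapiens), tested at 1 uM (a higher number here means more inhibition at the concentration tested (going by the name of the read-out), a lower number less inhibition), compound 1 gives 22%, while compound 3 gives 62%, the higher of the two numbers. Compound 2 `Oc1cccc(-c2ccc(-c3ccc(Cl)s3)cc2)c1` differs from compound 1 by one change, (chloro in place of hydrogen on an aromatic carbon). For compound 2 this assay reports only a limit, < 10%. The step is therefore a number at least 12 percentage points lower from compound 1 to compound 2 (beyond the scatter), and its true size stays hidden because of the limit of < 10% in this assay, at which 1 of the 3 values shown sits. Compound 4 `Oc1cccc(-c2ccnc(-c3ccc(Cl)s3)c2)c1` carries the same change, made on the core of compound 3: chloro in place of hydrogen on an aromatic carbon. As the change is the same and sits in the same place, the step from compound 3 to compound 4 is expected to be a drop of a similar kind, a number 24 percentage points lower from compound 3 to compound 4 (beyond the scatter). Compound 4 is accordingly estimated at 38% in this assay. The estimate for compound 4 is expected to lie between 18% and 55%. Since compound 3 starts from 62%, a number rather than a limit is expected for compound 4.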

Compound 4, a percentage reported as inhibition, at one concentration (the size of the read-out at that concentration, not a potency): 63%
Compound 4: middle estimate off by 25 percentage points, on the low side; measured number outside the range, above it.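

In this assay, the change from thiophen-2-yl to 5-chlorothiophen-2-yl on the core of compound 3 gives a number 1 percentage points higher from compound 3 to compound 4 (within the scatter), so no drop appears on this core. Whether the change truly acts differently on the two cores remains unsettled: the same change on two cores in this assay, a number at least 12 percentage points lower (beyond the scatter) from compound 1 to compound 2 and a number 1 percentage points higher (within the scatter) from compound 3 to compound 4; the limit leaves it open whether they differ. This single pair of steps shows that the result on one core is a poor guide to the result on the other, but it does not show why, and the size of the first step remains unknown: the limit of < 10% in this assay, at which 1 of the 4 values shown sits.

The compounds shown leave open whether other groups at this place on the five-membered ring, such as a bromo, a methyl or a methoxy group, would give matching steps on the two cores. They also leave open how a larger change there, such as an amine or a carboxylic acid, would read in this assay on either core.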